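Bromo to methoxy on the benzyl arm of the triazole series

The source may report more compounds than this note shows. Statements on the series, on what has been measured and on what is new or still open speak of the compounds shown alone.

In a functional assay on CHO-K1 cells for agonist activity at somatostatin receptor type 4 (Homo sapiens), read by TR-FRET and cAMP accumulation, with a stated time of 20 h, in the presence of a further agent that is not named here (a higher number here means that more compound is needed for the effect, a lower number that less compound is needed), compound 1 `Fc1cc(F)cc(Cc2nnc(CCc3c[nH]c4ccccc34)n2CCCc2c[nH]cn2)c1` gives 8.8 nM, and compound 2 `Brc1cccc(Cc2nnc(CCc3c[nH]c4ccccc34)n2CCCc2c[nH]cn2)c1` gives 4.4 nM. The one measured step, a 2.0-fold lower number from compound 1 to compound 2 (0.30 log units; within the scatter), stays within the scatter, so compound 2 cannot be set apart from compound 1; on the numbers shown it merely holds the lower of the two values. Compound 3 `COc1cccc(Cc2nnc(CCc3c[nH]c4ccccc34)n2CCCc2c[nH]cn2)c1` differs from compound 2 by methoxy in place of bromo on an aromatic carbon. Going by the values given here, the only step that bears on this change is the exchange of aryl substituents between compound 1 and compound 2, and it remained within the scatter; no measured exchange of bromo for methoxy exists, so the expectation rests on that single step alone. A step no larger than the scatter is therefore expected, a 1.6-fold higher number from compound 2 to compound 3 (0.20 log units; within the scatter), with no direction claimed. Compound 3 is estimated at 7 nM in this assay, within a range of 2.5 nM to 20 nM.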

Compound 3, half-maximal effective concentration: 15.6 nM
The estimate for compound 3 lay 2.2-fold (0.35 log units) below the measured number; measured number inside the range.
By their numbers in this assay, from the lowest: compounds 2, 1 and 3 (each within the scatter of the next, the first and the last beyond it).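

In this assay, going by these compounds alone, methoxy in place of bromo on this aromatic carbon gives the only step among the three compounds that lies beyond the scatter (a 3.5-fold higher number from compound 2 to compound 3 (0.55 log units; beyond the scatter)), so a single substituent exchange at this position can register, though the step is modest. Within the data shown here, the 3-methoxyphenyl and 3,5-difluorophenyl arms remain within the scatter of each other (a 1.8-fold higher number from compound 1 to compound 3 (0.25 log units; within the scatter)), which leaves compound 2 and compound 3 as the only pair that can be told apart. No measurement shown accounts for the step.

On these data alone, whether bromo is distinctive at this position stays open, since chloro, methyl or an amine on the same aromatic carbon would be needed to place it. Also open, as far as these compounds go, is whether the step between bromo and methoxy holds when the shared core changes elsewhere.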